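Benzyloxycarbonyl in place of cyano on the chain

The source may report more compounds than this note shows. Statements on the series, on what has been measured and on what is new or still open speak of the compounds shown alone.

Values in a functional assay on SEM cells (Homo sapiens) for cytotoxicity, with a stated time of 72 h (a higher number here means that more compound is needed for the effect, a lower number that less compound is needed), for the measured compounds:
- Compound 1 `C=C[C@@](C)(/C=C/c1ccc(O)c(CO)c1)CCC=C(C)C` gives > 36600 nM as a limit
- Compound 2 `C=C[C@@](C)(/C=C/c1ccc(O)c(C=O)c1)CCC=C(C)C` gives 8510 nM as a number
- Compound 3 `C=C[C@@](C)(/C=C/c1ccc(O)c(/C=C/C#N)c1)CCC=C(C)C` gives > 36600 nM as a limit

Compound 3 stands at the limit of > 36600 nM in this assay, at which 2 of the 3 values shown sit, and so has a limit and no number of its own.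

Compound 4 `C=C[C@@](C)(/C=C/c1ccc(O)c(/C=C/C(=O)OCc2ccccc2)c1)CCC=C(C)C` keeps the shared core and changes one group: benzyloxycarbonyl in place of cyano on a double-bonded chain carbon bound to a double-bonded chain carbon.

For the measured compounds named here, no measured step makes this exact swap. The nearest evidence comes from changes to the group on the aromatic carbon. Formyl in place of hydroxymethyl gave an at least 4.3-fold lower number from compound 1 to compound 2 (0.63 log units; beyond the scatter) and 2-cyanoethenyl in place of formyl gave an at least 4.3-fold higher number from compound 2 to compound 3 (0.63 log units; beyond the scatter) in the same assay. Replacing hydroxymethyl with 2-cyanoethenyl gave a step that the two limits leave unreadable from compound 1 to compound 3 and adds little.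

These steps show that changes in this part of the molecule can shift the result, but only compound 2 gives a number. A modest move to a lower number in this assay is therefore expected, with a real chance of another limit. The expected value for compound 4 is 20000 nM with an estimated range from 6000 nM to 36600 nM in this assay. This estimate means an at least 1.8-fold lower number from compound 3 to compound 4 (0.26 log units; that floor lies within the scatter) as the expected step.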

Compound 4, half-maximal effective concentration: > 36600 nM
Compound 4 was reported as a limit; the forecaster's own chance of this, stated with the estimate: 45%; middle value at least 1.8-fold (0.26 log units) away from the limit.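

In this assay compound 4 gives > 36600 nM, which is a limit and not a number. Compound 3 also has only a limit, so no step from compound 3 to compound 4 can be read: the limit of > 36600 nM in this assay, at which 3 of the 4 values shown sit.

The compounds shown leave open whether cyano or benzyloxycarbonyl on this chain gives the lower number.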